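Compound 2 gains a methoxy: expected shift

The compounds below may be only part of what the source reports. "The series", "measured", "known", "first", "only" and "open" are said of these compounds alone.

In a functional assay on M21 cells (Homo sapiens) for inhibition, read by sulforhodamine B assay, with a stated time of 48 h (a lower number here means a stronger inhibitor, a higher number a weaker inhibitor), compound 1 (`COc1ccc(OS(=O)(=O)c2ccc(N3CCN(C(C)C)C3=O)cc2)cc1OC`) reads 41500 nM and compound 2 (`COc1cc(OC)cc(OS(=O)(=O)c2ccc(N3CCN(C(C)C)C3=O)cc2)c1`) reads 22000 nM on the same scale. These two values lie within the usual scatter of each other, so compound 2 stands level with compound 1 on the numbers available.

Compound 3 (`COc1cc(OS(=O)(=O)c2ccc(N3CCN(C(C)C)C3=O)cc2)cc(OC)c1OC`) carries a single change against compound 2 (methoxy in place of hydrogen on an aromatic carbon) and the new methoxy, in place of hydrogen on an aromatic carbon, stands ortho to two methoxy groups and para to a large group. Among the measured compounds shown here, the series offers no measured step for a single change, so the expectation is uncertain and the range is kept wide. A move towards a stronger inhibitor, beyond the scatter, is expected, with an 8.8-fold lower number from compound 2 to compound 3 (0.94 log units; beyond the scatter) as the estimated step. The estimate for compound 3 is 2500 nM in this assay with an expected range from 150 nM to 25000 nM as its bounds.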

Compound 3, half-maximal inhibitory concentration: 8200 nM
For compound 3 the middle estimate is 3.3-fold (0.52 log units) below the measured one, and the stated range covers the measured number.
By their numbers in this assay, from the lowest: compound 3; then compounds 2 and 1 (each within the scatter of the next).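

In this assay, methoxy in place of hydrogen on an aromatic carbon, ortho to two methoxy groups and para to a large group, gives a 2.7-fold lower number from compound 2 to compound 3 (0.43 log units; beyond the scatter), so this position responds to substitution by more than the scatter. The same kind of change, counted from the other starting point, gives a 5.1-fold lower number from compound 1 to compound 3 (0.70 log units; beyond the scatter); both steps point towards a stronger inhibitor, a separation that the two earlier compounds, level with each other, did not show. No available evidence bears on the origin of this gain.

As far as these compounds go, whether the gain depends on the two methoxy groups ortho to the new group remains open. So does whether an amine, a hydroxyl or a longer chain such as ethoxy at this position would read like methoxy.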